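Cytotoxicity notes on two measured compounds and a dichloro analogue

The compounds below may be only part of what the source reports. "The series", "measured", "known", "first", "only" and "open" are said of these compounds alone.

Measured so far in an ADME assay on NHDF cells (Homo sapiens) for cytotoxicity, read by MTT assay, with a stated time of 72 h; on this read-out lower numbers stand for stronger inhibition and higher numbers for weaker inhibition (two compounds):
- compound 1 `COc1ccc(/C=C2\CCC/C(=C\c3ccc(Cl)cc3)C2=O)cc1OC` gives 11200 nM
- compound 2 `COc1ccc(/C=C2\CCC/C(=C\c3cccc(O)c3)C2=O)cc1OC` gives 6800 nM

For the measured compounds named here, compound 2 stands within the scatter of compound 1, the only other measured compound, as the single measured step shows: a 1.6-fold lower number from compound 1 to compound 2 (0.22 log units; within the scatter). Compound 3 (`COc1ccc(/C=C2\CCC/C(=C\c3ccc(Cl)c(Cl)c3)C2=O)cc1OC`) comes from compound 2 by one change: 3,4-dichlorophenyl in place of 3-hydroxyphenyl on a double-bonded chain carbon bound to a double-bonded ring carbon.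

Going by the values given here, that one step is the only evidence at this place, and it stayed within the scatter. Among the compounds with values here, no measured compound carries 3,4-dichlorophenyl, so its own contribution is unknown. The closest comparison is compound 1 at 11200 nM, which carries 4-chlorophenyl at the same place. With so small a measured step, no clear shift is expected in this assay, and any expected drift runs towards the number of compound 1. The expected move is a 1.3-fold higher number from compound 2 to compound 3 (0.12 log units; within the scatter) and thus nothing beyond the scatter. The estimate for compound 3 is 9000 nM (expected range 4000 nM to 20000 nM).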

Compound 3, half-maximal inhibitory concentration: 10100 nM
Compound 3: the middle estimate sits 1.1-fold (0.05 log units) below what was measured; the measured number falls inside the stated range.
By their numbers in this assay, from the lowest: compounds 2, 3 and 1 (each within the scatter of the next).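

In this assay, 3,4-dichlorophenyl in place of 3-hydroxyphenyl on a double-bonded chain carbon bound to a double-bonded ring carbon gives a 1.5-fold higher number from compound 2 to compound 3 (0.17 log units; within the scatter), so this change does not separate the two compounds, although the entering group counts 0 hydrogen-bond donors and 0 hydrogen-bond acceptors where the leaving group counts 1 of each. Chloro in place of hydrogen on an aromatic carbon gives a 1.1-fold lower number from compound 1 to compound 3 (0.04 log units; within the scatter), so the series now holds a direct comparison of 4-chlorophenyl and 3,4-dichlorophenyl at this place, and that comparison also shows no separation. No supporting measurement is available to account for either step.

From the compounds shown here alone, whether an amine or a carboxylic acid on the aromatic ring at this place, or a longer chain in place of that ring, would give a step beyond the scatter remains open. The compounds shown also leave open how changes elsewhere in the shared core would read out, and whether this flat picture holds for any other cell type.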